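Removing the ring from the side chain of compound 2

The source may report more compounds than this note shows. Statements on the series, on what has been measured and on what is new or still open speak of the compounds shown alone.

Measured so far in a functional assay on PC-3 cells (Homo sapiens) for antiproliferative activity, read by sulforhodamine B assay, with a stated time of 72 h; a lower number here means a stronger inhibitor, a higher number a weaker inhibitor:
compound 1 `COc1ncc(-c2ccc3ncc(NC(=O)CN4CCN(C)CC4)c(OC)c3c2)cc1NS(=O)(=O)c1ccc(F)cc1F` gives 1730 nM
compound 2 `COc1ncc(-c2ccc3ncc(NC(=O)CN4CCCC(O)C4)c(OC)c3c2)cc1NS(=O)(=O)c1ccc(F)cc1F` gives 1340 nM

Compound 2 lies within the scatter of compound 1, so the two cannot be ranked. Compound 3 `COc1ncc(-c2ccc3ncc(NC(C)=O)c(OC)c3c2)cc1NS(=O)(=O)c1ccc(F)cc1F` has hydrogen in place of 3-hydroxypiperidin-1-yl on a saturated chain carbon bound to a carbonyl carbon. Among the compounds with values here, the only measured step (a 1.3-fold lower number from compound 1 to compound 2 (0.11 log units; within the scatter)) exchanged one ring for another and stayed within the scatter. No measurement shows what losing the ring altogether does, so no direction can be favoured. The expected step (a 1.1-fold lower number from compound 2 to compound 3 (0.05 log units; within the scatter)) is none beyond the scatter, though with wide uncertainty. Compound 3 is estimated at 1200 nM (expected range 300 nM to 5000 nM).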

Compound 3, half-maximal inhibitory concentration: 1240 nM
The estimate for compound 3 lay 1.0-fold (0.01 log units) below the measured number; low and high end bracket the measured number.
By their numbers in this assay, from the lowest: compounds 3, 2 and 1 (each within the scatter of the next).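

In this assay, compound 3 shows that neither ring is needed on this saturated chain carbon bound to a carbonyl carbon: hydrogen in place of 3-hydroxypiperidin-1-yl gives a 1.1-fold lower number from compound 2 to compound 3 (0.03 log units; within the scatter), and hydrogen in place of 4-methylpiperazin-1-yl gives a 1.4-fold lower number from compound 1 to compound 3 (0.14 log units; within the scatter). Losing the ring altogether thus stays within the scatter, as exchanging one ring for another did. Nothing at hand explains this.

On these data alone, whether a carboxylic acid, a longer chain or an open-chain dimethylamino group on this carbon would move the number beyond the scatter remains open. So does whether the acetamido group itself matters.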